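Cyano in place of trifluoromethyl on the bromo compound

A few compounds are considered here, and "the series" means these few. Any claim that something is new, unique, unknown or untested is made for them only; others in the source may bear on it.

In a functional assay on HL-60 cells (Homo sapiens) for cytotoxicity, read by luminescence and CellTiter-Glo, with a stated time of 3 days (on this read-out higher numbers stand for weaker inhibition and lower numbers for stronger inhibition), compound 1 `O=C(Nc1ccc(C(F)(F)F)cc1)c1ccc(Br)cc1O` gives 360 nM and compound 2 `O=C(Nc1ccc(C(F)(F)F)cc1)c1ccc(F)cc1O` gives 680 nM. The step of a 1.9-fold higher number from compound 1 to compound 2 (0.28 log units; within the scatter) lies within the scatter, so these two compounds stand level. Compound 3 `N#Cc1ccc(NC(=O)c2ccc(Br)cc2O)cc1` differs from compound 1 by cyano in place of trifluoromethyl on an aromatic carbon, para to a large group. For the measured compounds named here, no measured step covers this change, and the fluoro in place of bromo step offers only a rough guide to size. The estimated step is a 1.7-fold higher number from compound 1 to compound 3 (0.22 log units; within the scatter), which is expected to stay within the scatter. For compound 3 the expected value is 600 nM, with an estimated range of 200 nM to 1800 nM.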

Compound 3, half-maximal inhibitory concentration: 1210 nM
For compound 3 the middle estimate is 2.0-fold (0.30 log units) below the measured one, within the range that was stated.
By their numbers in this assay, from the lowest: compounds 1, 2 and 3 (each within the scatter of the next, the first and the last beyond it).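

In this assay, for the compounds shown here, the aromatic carbon para to a large group gives the first step beyond the scatter, with cyano in place of trifluoromethyl on the bromo compound: a 3.4-fold higher number from compound 1 to compound 3 (0.53 log units; beyond the scatter). The number therefore responds to the group at this position, whereas the fluoro in place of bromo step, a 1.9-fold higher number from compound 1 to compound 2 (0.28 log units; within the scatter), did not separate its two compounds. Nothing measured here explains the step.

As far as these compounds go, whether the step holds on the fluoro compound remains open. So does how an amine or a carboxylic acid at this position would read.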